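Replacing the 1-chloroethenyl Group of Compound 3

The compounds below may be only part of what the source reports. "The series", "measured", "known", "first", "only" and "open" are said of these compounds alone.

Of the compounds shown here, three sharing one core have numbers so far in a functional assay on A549 cells (Homo sapiens) for inhibition, read by MTT assay, with a stated time of 72 h (a higher number here means a weaker inhibitor, a lower number a stronger inhibitor), and set the frame for this step. Compound 1 `C=C(Cl)C(=O)Nc1cc(Nc2nc3c(c(-c4cn(C)c5ccccc45)n2)CSCC3)c(OC)cc1N(C)CCN(C)C` gives 716 nM in this test, and compound 2 `C=C(Cl)C(=O)Nc1cc(Nc2nc3c(c(-c4cn(C)c5ccccc45)n2)CS(=O)(=O)CC3)c(OC)cc1N(C)CCN(C)C` gives 881 nM in the same test, two values within the usual scatter of each other. Compound 3 `C=C(Cl)C(=O)Nc1cc(Nc2nc3c(c(-c4cn(C)c5ccc(F)cc45)n2)CS(=O)(=O)CC3)c(OC)cc1N(C)CCN(C)C` stands at 3180 nM as the highest number of the three, which makes it the weakest inhibitor of this small set. Fluoro in place of hydrogen on an aromatic carbon goes with a 3.6-fold higher number from compound 2 to compound 3 (0.56 log units; beyond the scatter) as a modest step beyond the scatter.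

Compound 4 `CCC/C=C\C(=O)Nc1cc(Nc2nc3c(c(-c4cn(C)c5ccc(F)cc45)n2)CS(=O)(=O)CC3)c(OC)cc1N(C)CCN(C)C` keeps everything in compound 3 except one group, with pent-1-en-1-yl in place of 1-chloroethenyl on a carbonyl carbon as the whole difference. Among the measured compounds shown here, no measured pair changes anything at that place, and the one measured step lies elsewhere on the molecule, so the data give no direction for this change. The best anchor is therefore compound 3 at 3180 nM in this test, and no step beyond the scatter is expected. The expected change is a 1.3-fold higher number from compound 3 to compound 4 (0.10 log units; within the scatter) on this estimate, with wide uncertainty. Compound 4 is estimated at 4000 nM with an expected range of 1300 nM to 12000 nM in this test.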

Compound 4, half-maximal inhibitory concentration: 7570 nM
Beside the measured number, compound 4's estimate is 1.9-fold (0.28 log units) below it; the range from low to high includes it.
By their numbers in this assay, from the lowest: compounds 1 and 2 (each within the scatter of the next); then compound 3; then compound 4.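

In this assay, among the compounds shown here, pent-1-en-1-yl in place of 1-chloroethenyl on a carbonyl carbon goes with a 2.4-fold higher number from compound 3 to compound 4 (0.38 log units; beyond the scatter), the first measured step at this place, where the earlier compounds all carry the same group. It shows that the group on this carbonyl carbon can move the number beyond the scatter, here towards a weaker inhibitor, even though both groups hold one double bond outside aromatic rings and neither has hydrogen-bond donors or acceptors. Nothing measured alongside these numbers accounts for the shift.

Going by these compounds, this single pair cannot separate the loss of chlorine from the gain in chain length, and it rests only on the fluoro-bearing, sulfone-containing compound 3, so whether the same exchange would go the same way from compound 2 remains open. A plain ethenyl group would bear on the first question, while a shorter propenyl chain, or a chain ending in an amine, would show how far the number follows the length and the make-up of this group.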